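Fluoro in place of methoxy: compound 3 to compound 4

This account rests on a few compounds, and the source may have more. Where it says the series, first, only, none or still open, it means among the compounds named here.

Among the measured compounds shown here, in an ADME assay on cells (Hepatocyte, Mus musculus) for cytotoxicity, read by MTT assay, with a stated time of 24 h (a higher number here means that more compound is tolerated, a lower number that less compound is tolerated), compound 3 `COc1ccc(S(=O)(=O)n2c(-c3cn(-c4ccccc4)nc3-c3ccc(F)cc3)nc3ccccc32)cc1` gives 105000 nM as the lowest number so far. Compound 1 `Cc1ccc(-c2nn(-c3ccccc3)cc2-c2nc3ccccc3n2S(=O)(=O)c2ccc(Cl)cc2)cc1` sits nearest at 216000 nM with a gap just beyond the usual scatter. Compound 2 `Cc1ccc(-c2nn(-c3ccccc3)cc2-c2nc3ccccc3n2S(=O)(=O)c2ccc(Br)cc2)cc1` gives > 300000 nM and that is a limit of the assay, not a number.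

The next compound is compound 4 `O=S(=O)(c1ccc(F)cc1)n1c(-c2cn(-c3ccccc3)nc2-c2ccc(F)cc2)nc2ccccc21` and the change fluoro in place of methoxy on an aromatic carbon is fluoro in place of methoxy on an aromatic carbon. For the measured compounds named here, the only measured step, bromo in place of chloro on an aromatic carbon, is an at least 1.3-fold higher number from compound 1 to compound 2 (0.14 log units; that floor lies within the scatter) and offers little guidance. Compound 1 at 216000 nM has chloro where compound 3 has methoxy, but the two also differ in a second place, so only a small rise is expected. In this assay the expected step is a 1.4-fold higher number from compound 3 to compound 4 (0.15 log units; within the scatter) and would stay within the scatter. Compound 4 is estimated at 150000 nM with 70000 nM to 300000 nM as the expected range.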

Compound 4, half-maximal cytotoxic concentration: 174000 nM
The estimate for compound 4 lay 1.2-fold (0.06 log units) below the measured number, within the range that was stated.
By their numbers in this assay, from the lowest: compounds 3, 4 and 1 (each within the scatter of the next, the first and the last beyond it). At a limit, above all of these: compound 2.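

Swapping (4-methoxyphenyl)sulfonyl for (4-fluorophenyl)sulfonyl gives the first step at this position with a measured number at both ends: in this assay, there is a 1.7-fold higher number from compound 3 to compound 4 (0.22 log units; within the scatter). A methoxy and a fluoro at this place, para to a large group, therefore cannot be told apart in this assay, even though the two groups differ in size and in their hydrogen-bond acceptor count. Compound 2, from the only earlier step at this position, gives a limit and not a number: the limit of > 300000 nM in this assay, at which 1 of the 4 values shown sits.

On these data alone, whether an amine, a carboxylic acid or a longer chain at this place would also stay within the scatter remains open. As far as these compounds go, it is also open whether the swap of methoxy for fluoro would read the same on the core of compound 1.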